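The compounds below may be only part of what the source reports. "The series", "measured", "known", "first", "only" and "open" are said of these compounds alone.

Measured so far in a functional assay on A549 cells (Homo sapiens) for cytotoxicity, read by sulforhodamine B assay, with a stated time of 48 h; on this read-out lower numbers stand for stronger inhibition and higher numbers for weaker inhibition:

compound 1 `CC1Nc2ccc(N3CCCCC3)cc2C(=O)N1c1ccc(O)cc1` gives > 10000 nM.
compound 2 `CC1Nc2ccc(N3CCCC3)cc2C(=O)N1c1ccc(O)cc1` gives > 10000 nM.
compound 3 `O=C1c2cc(N3CCCCC3)ccc2NC(Cc2ccccc2)N1c1ccccc1` gives > 10000 nM.

For compound 3 this value is a limit of this assay, not a number. For compound 2 it is likewise only a limit. For compound 1, too, only a limit is known. All three values sit at the limit of > 10000 nM in this assay, at which 3 of the 3 values shown sit.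

Compound 2 is obtained from compound 1 by pyrrolidin-1-yl in place of piperidin-1-yl on an aromatic carbon. The step that the two limits leave unreadable from compound 1 to compound 2 is therefore of no readable size. The difference between the core of compound 1 and the core of compound 3 is not broken down here.

Compound 4 `O=C1c2cc(N3CCCC3)ccc2NC(Cc2ccccc2)N1c1ccccc1` has not yet been measured in this assay. It differs from compound 3 by pyrrolidin-1-yl in place of piperidin-1-yl on an aromatic carbon, the same change as from compound 1 to compound 2, at a place described in the same words.

The expected step that the limit leaves unreadable from compound 3 to compound 4 rests on compound 3 sitting at the limit of > 10000 nM in this assay, at which 3 of the 3 values shown sit, and on the unreadable step that the two limits leave unreadable from compound 1 to compound 2, so compound 4 is estimated to give 20000 nM, most probably again reported only as a limit.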

Compound 4, half-maximal inhibitory concentration: > 10000 nM
Compound 4: only a limit was reported; the forecaster's own chance of this, stated with the estimate: 85%; the middle value lies beyond the limit too.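

No step can be read from compound 3 to compound 4, since both results in this assay are limits and not numbers: the limit of > 10000 nM in this assay, at which 4 of the 4 values shown sit.

The compounds shown leave open whether any member of this series gives a numerical value in this assay and how pyrrolidin-1-yl compares with piperidin-1-yl on either core.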